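Ester-Linked Variants of a Shared Core: Solubility Outlook

The compounds below may be only part of what the source reports. "The series", "measured", "known", "first", "only" and "open" are said of these compounds alone.

Of the compounds shown here, two with one shared core have been measured in a physicochemical assay for solubility, read by HPLC, with a stated time of 4 h, at pH 9; on this read-out higher numbers stand for higher solubility and lower numbers for lower solubility. Compound 1 `COc1ccc2c(c1)c(CC(=O)OCOC(=O)C(C)(C)C)c(C)n2C(=O)c1ccc(Cl)cc1` gives 0.084 ug/mL. Compound 2 `COc1ccc2c(c1)c(CC(=O)OCOC(=O)OC(C)C)c(C)n2C(=O)c1ccc(Cl)cc1` gives 0.119 ug/mL. Among the measured compounds shown here, the only step available, a 1.4-fold higher number from compound 1 to compound 2 (0.15 log units; within the scatter), leaves compound 2 standing highest of the two numbers, though its nearest neighbour, compound 1, sits within the scatter of it.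

Compound 3 `COc1ccc2c(c1)c(CC(=O)OCCOC(C)=O)c(C)n2C(=O)c1ccc(Cl)cc1` has not been measured in this assay. It differs from compound 2 as follows: acetoxymethyl in place of (isopropoxycarbonyl)oxy on a saturated chain carbon bound to an oxygen next to a carbonyl group. For the measured compounds named here, no measured step covers this change; the one step recorded concerns a different part of the chain and was itself within the scatter. Compound 3 is therefore expected to move only modestly, with a step of a 1.0-fold higher number from compound 2 to compound 3 (0.00 log units; within the scatter) in this assay. The estimate for compound 3 is 0.12 ug/mL, with a range from 0.04 ug/mL to 0.4 ug/mL.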

Compound 3, solubility: 0.111 ug/mL
Compound 3: the middle estimate sits 1.1-fold (0.03 log units) above what was measured; the range from low to high includes it.
By their numbers in this assay, from the lowest: compounds 1, 3 and 2 (each within the scatter of the next).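

Putting acetoxymethyl in place of (isopropoxycarbonyl)oxy, on a saturated chain carbon bound to an oxygen next to a carbonyl group, gives a 1.1-fold lower number from compound 2 to compound 3 (0.03 log units; within the scatter) in this assay, and putting it in place of ((tert-butyl)carbonyl)oxy gives a 1.3-fold higher number from compound 1 to compound 3 (0.12 log units; within the scatter) there. The earlier step concerned only the end of the chain, whereas these two replace a stretch of it, and the read-out still does not separate any of the three compounds beyond the scatter. Nothing available explains why these numbers lie so close together.

The compounds shown all keep an ester at the end of the chain, so it remains open whether a terminal amine or carboxylic acid would separate from them on this read-out. From the compounds shown here alone, it also remains open whether a longer chain between the two ester groups would do so.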